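Replacing 4-fluorophenyl with furan-2-yl on the shared core

A few compounds are considered here, and "the series" means these few. Any claim that something is new, unique, unknown or untested is made for them only; others in the source may bear on it.

Measured in a functional assay on the whole organism with Mus musculus as the target; on this read-out lower numbers stand for an effect already at smaller amounts and higher numbers for an effect only at larger amounts of compound:
Compound 1 `CN(C)C(=O)Cn1c(-c2ccccc2)nc2cccnc21` gives 35 mg/kg
Compound 2 `CN(C)C(=O)Cn1c(-c2ccc(Br)cc2)nc2cccnc21` gives 7 mg/kg
Compound 3 `CN(C)C(=O)Cn1c(-c2ccc(F)cc2)nc2cccnc21` gives 40.5 mg/kg

Compound 3 lies level with compound 1 and clearly higher than compound 2, as a 1.2-fold higher number from compound 1 to compound 3 (0.06 log units; within the scatter) and a 5.8-fold higher number from compound 2 to compound 3 (0.76 log units; beyond the scatter) show. Among the compounds with values here, compound 4 `CN(C)C(=O)Cn1c(-c2ccco2)nc2cccnc21` carries furan-2-yl in place of 4-fluorophenyl on an aromatic carbon and no measured step replaces that whole group. The measured steps only exchange a substituent on it, and the bromo step, a 5.0-fold lower number from compound 1 to compound 2 (0.70 log units; beyond the scatter) is the only one from the parent that passes the scatter. No direction follows from these, so no step beyond the scatter is expected in this assay although a step of that size remains possible. The expected change is a 1.3-fold lower number from compound 3 to compound 4 (0.10 log units; within the scatter). Compound 4 is estimated at 32 mg/kg with an expected range from 11 mg/kg to 90 mg/kg.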

Compound 4, dose for half-maximal effect: > 100 mg/kg
Compound 4: a limit, no number; the forecaster's own chance of this, stated with the estimate: 8%; middle value at least 3.1-fold (0.49 log units) from the limit.
By their numbers in this assay, from the lowest: compound 2; then compounds 1 and 3 (each within the scatter of the next). At a limit, above all of these: compound 4.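

In this assay compound 4 gives only a limit and no number: the limit of > 100 mg/kg in this assay, at which 1 of the 4 values shown sits. The earlier compounds shown here only exchanged a substituent on the phenyl ring, whereas replacing the whole ring at this position, between two ring nitrogen atoms, with furan-2-yl also moves the number beyond the scatter (an at least 2.4-fold higher number from compound 3 to compound 4 (0.39 log units; beyond the scatter)) and (an at least 2.8-fold higher number from compound 1 to compound 4 (0.45 log units; beyond the scatter)). The gap is large against the bromo compound (an at least 14-fold higher number from compound 2 to compound 4 (1.15 log units; beyond the scatter)).

As far as these compounds go, how far compound 4 lies past its limit stays open. So does whether a thiophene or pyridine ring here would behave like furan-2-yl or like phenyl.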